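This account rests on a few compounds, and the source may have more. Where it says the series, first, only, none or still open, it means among the compounds named here.

Measured compounds:
Compound 1, `COc1cccc(/C(C)=C/CN(C)Cc2ccccc2)c1`: 10 nM
Compound 2, `COc1ccc(/C(C)=C/CN(C)Cc2ccccc2)cc1`: 5.25 nM
Compound 3, `COc1ccc(/C(C)=C/CN(C)C)cc1`: 806 nM

All three were tested in an assay on cell membranes for displacement of a labelled ligand from Sigma non-opioid intracellular receptor 1 (Cavia porcellus), read by scintillation counting, with a stated time of 150 min; on this read-out lower numbers stand for stronger inhibition and higher numbers for weaker inhibition. Compound 1 and compound 2 are built from the same atoms joined differently; the difference between their two cores is not broken down here, and their two values lie within the scatter of each other. Compound 3 differs from compound 2 in one place, (hydrogen in place of phenyl on a saturated chain carbon bound to an amine nitrogen), and this step gave a 150-fold higher number from compound 2 to compound 3 (2.19 log units; beyond the scatter). Compound 4, `COc1cccc(/C(C)=C/CN(C)C)c1`, has not yet been measured in this assay. Among the measured compounds shown here, it differs from compound 1 by hydrogen in place of phenyl on a saturated chain carbon bound to an amine nitrogen, the same change at the same place as the one from compound 2 to compound 3. For the measured compounds named here, since that single earlier step was large and beyond the scatter, the step from compound 1 to compound 4 is expected to be of a similar size, a 150-fold higher number from compound 1 to compound 4 (2.18 log units; beyond the scatter), resting only on the one step from compound 2 to compound 3. On that basis compound 4 is estimated at 1500 nM, with a plausible span from 400 nM to 5000 nM.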

Compound 4, inhibition constant: > 1000 nM
Compound 4 ended at the assay's limit; the forecaster's own chance of this, stated with the estimate: 5%; the middle value lies beyond the limit too.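

In this assay compound 4 gives > 1000 nM, which is a limit of the assay and not a number: the limit of > 1000 nM in this assay, at which 1 of the 4 values shown sits. Hydrogen in place of phenyl on a saturated chain carbon bound to an amine nitrogen gave an at least 100-fold higher number from compound 1 to compound 4 (2.00 log units; beyond the scatter), so the change again weakened binding strongly on this second core, and the large loss seen on the first core carried over in direction. Whether the loss is of equal size on the two cores is not shown: the same change on two cores in this assay, a 150-fold higher number (2.19 log units; beyond the scatter) from compound 2 to compound 3 and an at least 100-fold higher number (2.00 log units; beyond the scatter) from compound 1 to compound 4; the limit leaves it open whether they differ.

The compounds shown hold only benzyl or methyl at this place, so it remains open how a phenethyl group, a longer chain or a benzyl group with a chlorine on its ring would read. From the compounds shown here alone, it is also open whether the same change would carry as far on a core with a hydroxyl group in place of the methoxy group, since the evidence rests on only these two pairs.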